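The source may report more compounds than this note shows. Statements on the series, on what has been measured and on what is new or still open speak of the compounds shown alone.

Measured so far:
compound 1 `NC(=O)c1cc(NC(=O)c2cnc(Cl)nc2C(F)(F)F)cc(C(F)(F)F)c1` — 5000 nM
compound 2 `CCCCNC(=O)c1cc(NC(=O)c2cnc(Cl)nc2C(F)(F)F)cc(C(F)(F)F)c1` — > 10000 nM

In an assay on Jurkat cells for inhibition of nuclear factor NF-kappa-B p105 subunit (Homo sapiens) (a higher number here means a weaker inhibitor, a lower number a stronger inhibitor), compound 1 gives 5000 nM. For compound 2 only a limit of the assay is known, > 10000 nM; this is the limit (the limit of > 10000 nM in this assay, at which 1 of the 2 values shown sits). The step of an at least 2.0-fold higher number from compound 1 to compound 2 (0.30 log units; that floor lies within the scatter) thus carries a floor only. Compound 3 `CCOC(=O)c1cc(NC(=O)c2cnc(Cl)nc2C(F)(F)F)cc(C(F)(F)F)c1` is not yet measured in this assay. It differs from compound 2 by ethoxy in place of butylamino on a carbonyl carbon. Within the data shown here, the single measured step, from compound 1 to compound 2, alters the same carbonyl substituent, but compound 2 stands at a limit, so that step fixes no size for the move to compound 3. From the compounds shown here alone, the ethoxy group that enters is untested in the shared core. The expected step of an at least 1.2-fold lower number from compound 2 to compound 3 (0.09 log units; that floor lies within the scatter) is small, in either direction within the scatter, with a fair chance that this assay again reports only a limit. Compound 3 is estimated at 8000 nM, in the range 2500 nM to 25000 nM.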

Compound 3, half-maximal inhibitory concentration: 280 nM
Compound 3: the middle estimate sits 29-fold (1.46 log units) above what was measured; measured number below the stated range.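

In this assay, among these compounds, the group on the carbonyl carbon can shift the read-out well beyond the scatter, which the first step at this place could not show: ethoxy in place of amino gives an 18-fold lower number from compound 1 to compound 3 (1.25 log units; beyond the scatter). Ethoxy in place of butylamino gives an at least 35-fold lower number from compound 2 to compound 3 (1.55 log units; beyond the scatter), so among the three compounds shown, the ethoxy compound lies beyond the scatter from both carbonyl amides. Compound 2 carries a limit of the assay, so this second step is a floor and not a size: the limit of > 10000 nM in this assay, at which 1 of the 3 values shown sits.

The compounds shown leave open whether the result follows the oxygen on the carbonyl carbon or the length of the chain; ethylamino on one side, and methoxy or butoxy on the other, would separate the two. From the compounds shown here alone, how a carboxylic acid at the same place compares also remains open.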